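The compounds below may be only part of what the source reports. "The series", "measured", "known", "first", "only" and "open" are said of these compounds alone.

Working notes on the series. The shared core is present in compound 1 `CC(C)n1c(/C=C2/C(=O)Nc3ccccc32)nc2ccccc21` and in compound 2 `CCn1c(/C=C2/C(=O)Nc3ccc(C)cc32)nc2ccccc21`, which differ in the group on the benzimidazole nitrogen and in the substituent on the oxindole ring. In a functional assay on MCF7 cells (Homo sapiens) for cytotoxicity, read by MTT assay, with a stated time of 48 h (a higher number here means a weaker inhibitor, a lower number a stronger inhibitor), compound 1 gives 39500 nM. For compound 2 this assay returns only a limit, > 50000 nM, so compound 2 stands at the upper edge of the assay rather than at a number. Among the measured compounds shown here, this is the situation described by the limit of > 50000 nM in this assay, at which 1 of the 2 values shown sits, and it leaves no measured step within the pair.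

The next compound, compound 3 `CCn1c(/C=C2/C(=O)Nc3ccc([N+](=O)[O-])cc32)nc2ccccc21`, carries nitro in place of methyl on an aromatic carbon, in words: nitro in place of methyl on an aromatic carbon. For the measured compounds named here, no measured pair isolates this exchange. The expected step of an at least 1.6-fold lower number from compound 2 to compound 3 (0.22 log units; that floor lies within the scatter) is toward a lower number, of a size that may not clear the scatter. Compound 3 is estimated at 30000 nM, within a range of 8000 nM to 50000 nM.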

Compound 3, half-maximal inhibitory concentration: > 50000 nM
Compound 3: only a limit was reported; the forecaster's own chance of this, stated with the estimate: 40%; middle value at least 1.6-fold (0.22 log units) from the limit.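

No step can be read from compound 2 to compound 3 in this assay, since each returns only a limit of the assay: the limit of > 50000 nM in this assay, at which 2 of the 3 values shown sit.

The compounds shown leave open what nitro in place of methyl on an aromatic carbon changes in this assay.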